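Fused bicyclic imidazole variants on the shared core

The compounds below may be only part of what the source reports. "The series", "measured", "known", "first", "only" and "open" are said of these compounds alone.

Among the compounds with values here, compound 3 `COc1ccc(Br)cc1CCc1c(Cl)cccc1-c1ncc2n1CCC2` gives 180 nM in an assay on isolated protein for binding affinity to Melanocortin receptor 4 (Homo sapiens) (on this read-out higher numbers stand for weaker inhibition and lower numbers for stronger inhibition), the lowest of the three numbers so far. Compound 1 `COc1ccc(Br)cc1CCc1c(Cl)cccc1-c1nccn1C(C)C` gives 670 nM in this assay, and compound 2 `COc1ccc(Br)cc1CCc1c(Cl)cccc1-c1nccn1CC1CC1` gives 2000 nM. The steps are a 3.7-fold lower number from compound 1 to compound 3 (0.57 log units; beyond the scatter) and an 11-fold lower number from compound 2 to compound 3 (1.05 log units; beyond the scatter), so compound 3 stands clear of both on this read-out; the step of a 3.0-fold higher number from compound 1 to compound 2 (0.47 log units; beyond the scatter) shows that adding one carbon to the group on the aromatic nitrogen went the other way.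

Compound 4 `COc1ccc(Br)cc1CCc1c(Cl)cccc1-c1ncc2n1CCCC2` is not yet measured. It differs from compound 3 by a group of 9 heavy atoms (7 carbon, 2 nitrogen; one five-membered aromatic ring with 2 hetero atoms, one six-membered non-aromatic ring with 1 hetero atom) in place of a group of 8 heavy atoms (6 carbon, 2 nitrogen; one five-membered non-aromatic ring with 1 hetero atom, one five-membered aromatic ring with 2 hetero atoms), on an aromatic carbon, that is, a six-membered non-aromatic ring with one hetero atom in place of the five-membered one. Within the data shown here, no measured pair covers this change directly. The closest comparison is compound 1 against compound 2 a 3.0-fold higher number from compound 1 to compound 2 (0.47 log units; beyond the scatter), where one added carbon gave a modest higher number; compound 3 against compound 1 a 3.7-fold lower number from compound 1 to compound 3 (0.57 log units; beyond the scatter) shows the fused arrangement itself is favourable. A modest step is therefore expected for compound 4 in this assay, more likely toward a higher number than a lower one, a 1.7-fold higher number from compound 3 to compound 4 (0.22 log units; within the scatter). Compound 4 is estimated at 300 nM, within 90 nM to 1000 nM.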

Compound 4, inhibition constant: 340 nM
The estimate for compound 4 lay 1.1-fold (0.05 log units) below the measured number, within the range that was stated.
By their numbers in this assay, from the lowest: compounds 3, 4 and 1 (each within the scatter of the next, the first and the last beyond it); then compound 2.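

Ring size at this position, on an aromatic carbon of a six-membered aromatic ring of carbon only, is not sharply defined in this assay: the six-membered non-aromatic ring in place of the five-membered one gives (a 1.9-fold higher number from compound 3 to compound 4 (0.28 log units; within the scatter)). Fusion alone therefore does not set the read-out: compound 3 stood beyond the scatter from compound 1, but the larger ring does not (a 2.0-fold lower number from compound 1 to compound 4 (0.29 log units; within the scatter)), while the separation from the cyclopropylmethyl group remains (a 5.9-fold lower number from compound 2 to compound 4 (0.77 log units; beyond the scatter)). No measurement available here accounts for these differences.

The compounds shown leave open how a seven-membered non-aromatic ring would read in this assay. Also open, on these data alone, is whether an amine or a hydroxyl group on the fused ring would move the number beyond the scatter from compound 3.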